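A few compounds are considered here, and "the series" means these few. Any claim that something is new, unique, unknown or untested is made for them only; others in the source may bear on it.

Measured so far:
Compound 1 `CON1C[C@H](NC(=O)OCCCCC2CCCCC2)C1=O` — 16 nM
Compound 2 `C[C@H]1[C@H](NC(=O)OCCCCC2CCCCC2)C(=O)N1OCCCS(C)(=O)=O` — 49 nM

In an assay on HEK293 cells for inhibition of N-acylethanolamine-hydrolyzing acid amidase (Homo sapiens), read by fluorescence, with stated times of 10 min and 50 min (on this read-out lower numbers stand for stronger inhibition and higher numbers for weaker inhibition), compound 1 gives 16 nM. Among the measured compounds shown here, compound 2, which carries a methyl on the ring of the shared core and a 3-(methylsulfonyl)propyl on the ring oxygen, gives 49 nM in this assay, the higher of the two numbers, with compound 1 the only neighbour for comparison.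

Compound 3 `C[C@H]1[C@H](NC(=O)OCCCCC2CCCCC2)C(=O)N1Oc1ccc(S(C)(=O)=O)cc1` keeps the core and the carbamate chain of compound 2 and differs from it at a single place: 4-(methylsulfonyl)phenyl in place of 3-(methylsulfonyl)propyl on an oxygen

For the measured compounds named here, no step between two measured compounds mirrors this exchange, so the expectation rests on compound 2 alone. The step from compound 2 to compound 3 is expected to be a 1.2-fold higher number from compound 2 to compound 3 (0.09 log units; within the scatter), in either direction no more than the usual scatter would allow. Compound 3 is therefore estimated at 60 nM in this assay, within a range from 20 nM to 200 nM.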

Compound 3, half-maximal inhibitory concentration in the N-acylethanolamine-hydrolyzing acid amidase assay: 6 nM
Beside the measured number, compound 3's estimate is 10-fold (1.00 log units) above it; measured number outside the range, below it.
By their numbers in the N-acylethanolamine-hydrolyzing acid amidase assay, from the lowest: compound 3; then compound 1; then compound 2.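

At the place on an oxygen whose other neighbours are an amide-type nitrogen in a ring, the N-acylethanolamine-hydrolyzing acid amidase assay shows an 8.2-fold lower number from compound 2 to compound 3 (0.91 log units; beyond the scatter), so the group on this oxygen can move the read-out beyond the scatter, and a six-membered aromatic ring can take the place of the open chain without loss. In a physicochemical assay for metabolic stability, read by HPLC, in phosphate buffer, with a stated time of 24 h, at 37 degrees C, at pH 7.4, tested at 1 uM, in the presence of a further agent that is not named here (on this read-out higher numbers stand for a longer-lived compound and lower numbers for a shorter-lived compound), compound 2 gives > 24 h, which is a limit of the assay and not a number. In the physicochemical assay compound 3 gives 12.1 h. In the physicochemical assay the same exchange reads an at least 1.9-fold lower number from compound 2 to compound 3 (0.29 log units; that floor lies within the scatter), and only a floor can be stated for this step: the limit of > 24 h in the physicochemical assay, at which 1 of the 2 values shown sits.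

Going by these compounds, it remains open whether 4-(methylsulfonyl)phenyl would give a similar step on the core of compound 1, which lacks the methyl on the ring. Also open, on these data alone, is how a pyridine, or a phenyl carrying an amine or a carboxylic acid in place of methylsulfonyl, would read on this oxygen.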